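Swapping Allyl for Hydrogen on Compound 2

This account rests on a few compounds, and the source may have more. Where it says the series, first, only, none or still open, it means among the compounds named here.

Compound 1 (`O=C(c1cccnc1)c1cc(Cl)ccc1O`) gives 29000 nM
Compound 2 (`C=CCOc1ccc(C)cc1C(=O)c1cccnc1`) gives 84000 nM

In a functional assay on MCF7 cells (Homo sapiens) for cytotoxicity, read by sulforhodamine B assay, with a stated time of 48 h (on this read-out lower numbers stand for stronger inhibition and higher numbers for weaker inhibition), compound 2 has the higher of the two numbers, so it is the weaker of the pair, and its gap to compound 1 lies beyond the scatter. Compound 3 (`Cc1ccc(O)c(C(=O)c2cccnc2)c1`) goes from allyloxy to hydroxy, with hydrogen in place of allyl on an oxygen on an aromatic ring. Going by the values given here, no measured pair shows this change alone. Compound 1 also carries a hydroxy group and gives 29000 nM so the step expected in this assay is a modest fall (estimated a 2.2-fold lower number from compound 2 to compound 3 (0.34 log units; beyond the scatter)) close to the edge of the scatter. Compound 3 is estimated at 38000 nM (expected range 14000 nM to 90000 nM).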

Compound 3, half-maximal inhibitory concentration: 8040 nM
For compound 3 the middle estimate is 4.7-fold (0.67 log units) above the measured one; the measured number lies below the stated range.
By their numbers in this assay, from the lowest: compound 3; then compound 1; then compound 2.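

In this assay the allyl on the oxygen on an aromatic ring proves costly: putting hydrogen there gives a 10-fold lower number from compound 2 to compound 3 (1.02 log units; beyond the scatter) in a large step. The group on the aromatic carbon also counts, since methyl in place of chloro gives a 3.6-fold lower number from compound 1 to compound 3 (0.56 log units; beyond the scatter) in a modest step. Nothing available here explains either step.

As far as these compounds go, what stays open is where a longer chain on that oxygen, or an amine in place of the hydroxy group, would fall relative to compound 2 and compound 3.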